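The source may hold more compounds than are shown below. What is called first, only, known or untested is meant among the compounds shown, and "the series" means these compounds.

The numbers here come from a functional assay on the whole organism for antagonist activity, with Mus musculus as the target; on this read-out higher numbers stand for an effect only at larger amounts of compound and lower numbers for an effect already at smaller amounts. Within the data shown here, in this test compound 1 `CCC(=O)N(c1ccc(F)cc1)C1CCCC1N(C)C` gives 0.08 mg/kg, the lower of the only two actual numbers available. Compound 3 `CCC(=O)N(c1ccc(F)c(Cl)c1)C1CCCC1N(C)C` gives 2 mg/kg. Compound 2 `CCC(=O)N(c1c(F)c(F)c(F)c(F)c1F)C1CCCC1N(C)C`, which carries more fluorine on its aromatic ring, is reported only as a limit, > 50 mg/kg.

The open question concerns compound 4 `CCC(=O)N(c1ccc(C(C)=O)cc1)C1CCCC1N(C)C`, in which acetyl takes the place of fluoro on an aromatic carbon of the ring, para to a large group: acetyl in place of fluoro on an aromatic carbon. Among the measured compounds shown here, no measured compound makes this exact change, so the evidence is indirect. The closest single-place comparison is a 25-fold higher number from compound 1 to compound 3 (1.40 log units; beyond the scatter), seen when chloro replaces hydrogen on an aromatic carbon. For the measured compounds named here, that large step is a different change from the one in compound 4, so it serves only as a rough guide. Going by the values given here, still, compound 2 and compound 3 both show higher numbers than compound 1, and no measured compound goes against this. A large step towards a higher number is therefore expected, of roughly the same size. The expected change is a 38-fold higher number from compound 1 to compound 4 (1.57 log units; beyond the scatter). For compound 4 the estimated value is 3 mg/kg, with an expected range from 0.4 mg/kg to 30 mg/kg.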

Compound 4, dose for half-maximal effect: 40 mg/kg
Compound 4: the middle estimate sits 13-fold (1.12 log units) below what was measured, and the stated range ends below it.
By their numbers in this assay, from the lowest: compound 1; then compound 3; then compound 4. At a limit, above all of these: compound 2.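

In this assay, putting acetyl in place of the fluoro on this carbon, para to a large group, gives a 500-fold higher number from compound 1 to compound 4 (2.70 log units; beyond the scatter). Among the single-place changes shown, this is the only one that replaces the fluoro itself, and it shows that this one carbon strongly affects the dose needed: the other single-place change leaves the fluoro in place, puts chloro in place of a ring hydrogen, and gives a smaller shift, a 25-fold higher number from compound 1 to compound 3 (1.40 log units; beyond the scatter). Among these compounds, compound 2 remains the only compound reported solely as a limit: the limit of > 50 mg/kg in this assay, at which 1 of the 4 values shown sits.

Because acetyl differs from fluoro in several ways at once, with more heavy atoms, a double bond and a hydrogen-bond acceptor, this single step cannot show which of these differences matters. As far as these compounds go, it also remains open whether a small methyl or an amine on the same carbon would stay close to compound 1 or shift as far as compound 4, and such a comparison would begin to separate the size of the group from the presence of the acceptor.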